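Swapping Hydroxy for Amino on a Shared Core

The compounds below may be only part of what the source reports. "The series", "measured", "known", "first", "only" and "open" are said of these compounds alone.

compound 1 `COc1ccc(-c2cc3ccccc3c(-c3cccc(O)c3)n2)cc1`: 580 nM
compound 2 `COc1cc(OC)cc(-c2cc3ccccc3c(-c3cccc(OC)c3)n2)c1`: 1120 nM
compound 3 `COc1ccc(-c2cc3cc(C)ccc3c(-c3cccc(O)c3)n2)cc1OC`: 4340 nM

These three compounds share a common core and were all tested in a functional assay on T47D cells (Homo sapiens) for cytotoxicity, read by CCK-8 assay and cell counting, with a stated time of 72 h; on this read-out higher numbers stand for weaker inhibition and lower numbers for stronger inhibition. In this assay compound 3 gives 4340 nM, the highest number of the three and therefore the weakest inhibition in this set. The nearest to it is compound 2 and the furthest is compound 1; both of these gaps lie beyond the usual scatter, so compound 3 stands clearly apart.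

The next compound, compound 4 `COc1ccc(-c2cc3cc(C)ccc3c(-c3cccc(N)c3)n2)cc1OC`, differs from compound 3 in one place: amino in place of hydroxy on an aromatic carbon. Going by the values given here, no pair of measured compounds shows this same exchange, so there is nothing measured here that tells how large a step it brings. In this assay a step of no more than the usual scatter is expected, in either direction. The expected change is a 1.2-fold higher number from compound 3 to compound 4 (0.06 log units; within the scatter). Compound 4 is thus estimated at 5000 nM, within a range from 1500 nM to 16000 nM.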

Compound 4, half-maximal inhibitory concentration: 450 nM
The estimate for compound 4 lay 11-fold (1.05 log units) above the measured number, and the stated range ends above it.
By their numbers in this assay, from the lowest: compounds 4, 1 and 2 (each within the scatter of the next, the first and the last beyond it); then compound 3.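

On the 3-hydroxyphenyl group of compound 3, changing to 3-aminophenyl gives in this assay a 9.6-fold lower number from compound 3 to compound 4 (0.98 log units; beyond the scatter). This shows that a change of a single atom at this place on the ring can clearly shift the read-out, even though hydroxy and amino have the same counts of heavy atoms, hydrogen-bond donors and hydrogen-bond acceptors. Nothing measured here accounts for the size of this step.

On these data alone, this exchange is seen in one pair only, and it remains open whether it would bring a similar step on the core of compound 1, which lacks the methyl group and one methoxy group of compound 3. Also open, as far as these compounds go, is how other groups at this place, such as a methylamino group or a carboxylic acid, would compare with amino.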